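The source may hold more compounds than are shown below. What is called first, only, known or untested is meant among the compounds shown, and "the series" means these compounds.

Measured compounds:
compound 1 `CCCC(=O)c1ccc(OCCCCOc2ccc(C(=O)O)cc2C)c(C)c1O` gives 104 nM in an assay on HEK293 cells for positive allosteric modulation of metabotropic glutamate receptor 2 (Rattus norvegicus), read by thallium flux, with a stated time of 2.5 min; a higher number here means that more compound is needed for the effect, a lower number that less compound is needed
compound 2 `Cc1c(OCCCCOc2ccc(F)c(C(=O)O)c2)ccc(C(=O)CC2CCCC2)c1O` gives 699 nM in this assay
compound 3 `Cc1c(OCCCCOc2ccc(F)c(C(=O)O)c2)ccc(C(=O)CC2CCCC2)c1C` gives "not determined" (no result reported) in this assay

Compound 1 holds the lowest of the two numbers available; compound 2 sits well above it, a gap that is beyond the usual scatter of this measurement. Among the measured compounds shown here, compound 3 contributes no number, so only compound 1 and compound 2 describe the series so far. For the measured compounds named here, no pair of measured compounds differs in a single place, so there is no directly comparable step to lean on.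

Compound 4 `Cc1cc(C(=O)O)ccc1OCCCCOc1ccc(C(=O)CC(C)C)c(O)c1C` is the next one to be measured. Relative to compound 1 the change is methyl in place of hydrogen on a saturated chain carbon bound to two saturated chain carbons, that is, propylcarbonyl becomes isobutylcarbonyl while the rest of the shared core is kept. Nothing measured here speaks to the effect of adding a methyl at this place, so the expectation rests on the size of the change alone: a single added carbon on a saturated chain, no ring, no new donor or acceptor. The step of a 1.3-fold higher number from compound 1 to compound 4 (0.10 log units; within the scatter) is expected to be small, most likely within the scatter, with no clear direction. Compound 4 is therefore estimated at 130 nM, in the range 50 nM to 350 nM.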

Compound 4, half-maximal effective concentration: 192 nM
The estimate for compound 4 lay 1.5-fold (0.17 log units) below the measured number, within the range that was stated.
By their numbers in this assay, from the lowest: compounds 1 and 4 (each within the scatter of the next); then compound 2.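

Propylcarbonyl to isobutylcarbonyl, methyl in place of hydrogen on a saturated chain carbon bound to two saturated chain carbons, gives the first step in this series that differs in one place only: a 1.8-fold higher number from compound 1 to compound 4 (0.27 log units; within the scatter) in this assay. The series therefore now has a direct reading at this position, and it shows that this single added methyl, with no ring and no new donor or acceptor, leaves compound 1 and compound 4 indistinguishable in this measurement, so the chain carbon accepts this branch without a change that can be told from the scatter. Among the compounds shown here, nothing on hand gives a reason for this outcome, and the reading covers only this one change at this one place.

From the compounds shown here alone, one step cannot show how far the position stays this permissive: whether a longer chain, an amine or a carboxylic acid on the same chain carbon would also stay within the scatter of compound 1 remains open. For the compounds shown here, also open is whether the same methyl would behave alike on a core carrying other changes, since no second pair of compounds repeats this step.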